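Replacing a side chain with ethyl on compound 2

This account rests on a few compounds, and the source may have more. Where it says the series, first, only, none or still open, it means among the compounds named here.

Compound 2 `CCC1=C(N2CC2)C(=O)C(C(COC(N)=O)OC)=C(N2CC2)C1=O` gives 5.62 in a functional assay on L1210 cells (Mus musculus), with a stated time of 1 days; a higher number here means a more potent compound, by a factor of ten per unit of this negative logarithm, a lower number a less potent compound; among the three measured compounds, its step to compound 3 lies within the scatter and its step to compound 1 beyond it. Compound 3 `CCOC(COC(N)=O)C1=C(N2CC2)C(=O)C(CC)=C(N2CC2)C1=O` gives 5.4 and compound 1 `CCCC1=C(N2CC2)C(=O)C(C(COC(N)=O)OC)=C(N2CC2)C1=O` gives 5.01 in this assay. The step of a number 0.61 log units higher from compound 1 to compound 2 (beyond the scatter) is beyond the scatter, whereas a number 0.22 log units lower from compound 2 to compound 3 (within the scatter) is within it. Compound 4 `CCC1=C(N2CC2)C(=O)C(CC)=C(N2CC2)C1=O` differs from compound 2 by a group of 2 heavy atoms (2 carbon; no ring) in place of a group of 8 heavy atoms (4 carbon, 1 nitrogen, 3 oxygen; no ring), on a double-bonded ring carbon. Both measured steps are small edits on or near that side chain; neither removes it outright, so they bear only loosely on this change, and no close parallel exists in the data. Compound 4 is therefore expected at 5.5, with a range of 4.8 to 6.2. That estimate means a step of a number 0.12 log units lower from compound 2 to compound 4 (within the scatter), expected to stay within the scatter.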

Compound 4, logarithm of the reciprocal of the active concentration, log(1/C): 4.94
Compound 4: the middle estimate sits 0.56 log units above what was measured; low and high end bracket the measured number.
By their numbers in this assay, from the lowest: compounds 4 and 1 (each within the scatter of the next); then compounds 3 and 2 (each within the scatter of the next).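

In this assay, putting ethyl in place of the whole side chain on this double-bonded ring carbon gives a number 0.68 log units lower from compound 2 to compound 4 (beyond the scatter). The small edit within that side chain, seen from compound 2 to compound 3, stayed within the scatter, so only the full replacement shows that this position is sensitive to what it carries. Nothing measured here explains the change.

The compounds shown leave open which part of the departing group matters, and whether a hydroxymethyl group or an amine at this carbon would match compound 2.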